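A few compounds are considered here, and "the series" means these few. Any claim that something is new, unique, unknown or untested is made for them only; others in the source may bear on it.

Of the compounds shown here, three sharing one core have been measured in an ADME assay on HEL cells (Homo sapiens) for cytotoxicity; on this read-out lower numbers stand for higher toxicity in this test and higher numbers for lower toxicity in this test. Compound 1 `O=C(COc1cccc2ccccc12)N/N=C/c1ccccc1O` gives 20 ug/mL. Compound 2 `O=C(COc1cccc2ccccc12)N/N=C/c1ccccc1` gives 100 ug/mL, and compound 3 `O=C(COc1cccc2ccccc12)N/N=C/c1ccccc1Cl` gives 100 ug/mL. Compound 3 thus stands level with compound 2 at the digits shown, the two together being the highest of the three numbers; its furthest neighbour is compound 1, from which the step of a 5.0-fold higher number from compound 1 to compound 3 (0.70 log units; beyond the scatter) runs, while no change at the digits printed from compound 2 to compound 3 (within the scatter).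

Compound 4 `O=C(COc1cccc2ccccc12)N/N=C/c1ccccc1[N+](=O)[O-]` is not yet measured. It differs from compound 3 in one place: nitro in place of chloro on an aromatic carbon. Among the compounds with values here, no measured step exchanges a nitro group, so the nearest guidance comes from the other substitutions at this aromatic carbon: no change at the digits printed from compound 2 to compound 3 (within the scatter), whereas a 5.0-fold higher number from compound 1 to compound 2 (0.70 log units; beyond the scatter) and a 5.0-fold higher number from compound 1 to compound 3 (0.70 log units; beyond the scatter) both run in the same direction from the hydroxy-bearing compound 1. With the hydroxy group absent from both compound 3 and compound 4, the step of no change at the digits printed from compound 3 to compound 4 (within the scatter) is expected to remain within the scatter.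

Compound 4 is therefore estimated to give 100 ug/mL in this assay, expected to fall between 50 ug/mL and 200 ug/mL.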

Compound 4, minimum cytotoxic concentration in the HEL assay: 20 ug/mL
The estimate for compound 4 lay 5.0-fold (0.70 log units) above the measured number; measured number below the stated range.
By their numbers in the HEL assay, from the lowest: compounds 1 and 4 (each within the scatter of the next); then compounds 2 and 3 (each within the scatter of the next).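

In the HEL assay this aromatic carbon does not treat every group without a hydroxy alike: a 5.0-fold lower number from compound 2 to compound 4 (0.70 log units; beyond the scatter), and a 5.0-fold lower number from compound 3 to compound 4 (0.70 log units; beyond the scatter), so nitro parts from chloro and hydrogen. In the HEL assay the hydroxy group also proves not to be the only substituent here that goes with the low number, as no change at the digits printed from compound 1 to compound 4 (within the scatter). In a physicochemical assay for lipophilicity, measured as octanol-water partition (a lower number here means a more polar compound, a higher number a more lipophilic compound), compound 3 gives 4.54 and compound 4 gives 3.97, which is a number 0.57 log units lower from compound 3 to compound 4 (beyond the scatter).

From the compounds shown here alone, whether an amine or a carboxylic acid on this aromatic carbon would side with hydroxy and nitro or with chloro and hydrogen stays open. Going by these compounds, whether the partition coefficient has any link with the cytotoxicity read-out also stays open, for a single pair does not settle that.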